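A trifluoromethyl group in place of dimethylamino

The source may report more compounds than this note shows. Statements on the series, on what has been measured and on what is new or still open speak of the compounds shown alone.

Of the compounds shown here, three sharing one core have been measured in a functional assay on A549 cells (Homo sapiens) for inhibition, read by CCK-8 assay, with a stated time of 48 h; a lower number here means a stronger inhibitor, a higher number a weaker inhibitor. Compound 1 `Cn1ccc2cc(-c3cc4nccc(-c5ccc(F)cc5)n4n3)ccc21` gives 3520 nM in this assay. Compound 2 `COc1cc(-c2ccnc3cc(-c4ccc(C(C)=O)cc4)nn23)cc(OC)c1OC` gives 4100 nM in this assay. Compound 3 `COc1cc(-c2ccnc3cc(-c4ccc(N(C)C)cc4)nn23)cc(OC)c1OC` gives 1100 nM in this assay, the lowest of the three numbers, so compound 3 is the strongest inhibitor among them.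

Going by the values given here, the one step between measured compounds that differ in a single place is a 3.7-fold lower number from compound 2 to compound 3 (0.57 log units; beyond the scatter), and it lies beyond the scatter: a group on the same aromatic carbon was swapped and the number fell.

Compound 4 `COc1cc(-c2ccnc3cc(-c4ccc(C(F)(F)F)cc4)nn23)cc(OC)c1OC` has not yet been measured. It differs from compound 3 as follows: trifluoromethyl in place of dimethylamino on an aromatic carbon. Among the compounds with values here, no measured pair shows what a trifluoromethyl group does at this place. What is known is that the dimethylamino group now being removed is the very group whose arrival gave the lower number in the step from compound 2 to compound 3. Removing it is therefore expected to move the number back upward by a step of similar size, a 3.2-fold higher number from compound 3 to compound 4 (0.50 log units; beyond the scatter), rather than to keep compound 3's level. Compound 4 is accordingly estimated at 3500 nM, with a range from 1500 nM to 8000 nM.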

Compound 4, half-maximal inhibitory concentration: 2070 nM
Compound 4: the middle estimate sits 1.7-fold (0.23 log units) above what was measured, and the stated range covers the measured number.
By their numbers in this assay, from the lowest: compounds 3, 4, 1 and 2 (each within the scatter of the next, the first and the last beyond it).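

In this assay this position now carries three different groups on the same core, and compound 4 falls between the two earlier results without being separable from either: the change shows a 1.9-fold higher number from compound 3 to compound 4 (0.27 log units; within the scatter), while the comparison with the acetyl compound shows a 2.0-fold lower number from compound 2 to compound 4 (0.30 log units; within the scatter). So dimethylamino can be exchanged for trifluoromethyl here without a change that stands clear of the scatter, and the data do not show that dimethylamino is needed to reach a number in this range, even though acetyl and dimethylamino remain separated by more than the scatter. No measurement shown here explains how any of these three groups affects the number.

Still open, from the compounds shown here alone, is whether a carboxylic acid, a primary amine or a longer chain such as butoxy on the same aromatic carbon would move the number clearly away from compound 3. Also open, going by these compounds, is whether trifluoromethyl and dimethylamino would stay this close if the same exchange were made on a core carrying a different group in place of the trimethoxyphenyl ring.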